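Changing the Ring on the Carbonyl Carbon

The compounds below may be only part of what the source reports. "The series", "measured", "known", "first", "only" and "open" are said of these compounds alone.

Among the measured compounds shown here, compound 1 `Cc1ccccc1C(=O)N(C(=S)OCCN1C(=O)c2ccccc2C1=O)c1ccc(Cl)cc1` gives 21000 nM in an ADME assay on MT4 cells (Homo sapiens) for cytotoxicity, read by MTT assay (a lower number here means that less compound is tolerated, a higher number that more compound is tolerated), the lowest of the three numbers measured so far. Compound 2 `O=C1c2ccccc2C(=O)N1CCOC(=S)N(C(=O)c1cc(F)ccc1F)c1ccc(Cl)cc1` gives 54000 nM, and compound 3 `O=C1c2ccccc2C(=O)N1CCOC(=S)N(C(=O)c1ccc(F)c(F)c1)c1ccc(Cl)cc1` gives 52000 nM. Compound 4 `COc1cccc(OC)c1C(=O)N(C(=S)OCCN1C(=O)c2ccccc2C1=O)c1ccc(Cl)cc1` differs from compound 1 by a single change: 2,6-dimethoxyphenyl in place of 2-methylphenyl on a carbonyl carbon. For the measured compounds named here, the steps that bear on this change are the two in which the same 2-methylphenyl was replaced by another ring on the carbonyl carbon: a 2.6-fold higher number from compound 1 to compound 2 (0.41 log units; beyond the scatter) and a 2.5-fold higher number from compound 1 to compound 3 (0.39 log units; beyond the scatter). Both were modest and pointed the same way. A modest rise beyond the scatter is therefore expected for compound 4, namely a 2.0-fold higher number from compound 1 to compound 4 (0.30 log units; within the scatter). Compound 4 is estimated at 42000 nM, with a range from 20000 nM to 90000 nM.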

Compound 4, half-maximal cytotoxic concentration: 69000 nM
Estimate against measurement, compound 4: 1.6-fold (0.22 log units) below; low and high end bracket the measured number.
By their numbers in this assay, from the lowest: compound 1; then compounds 3, 2 and 4 (each within the scatter of the next).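

In this assay, among the compounds shown here, 2,6-dimethoxyphenyl is the first ring at this carbonyl carbon to bring oxygen atoms, and it gives a 3.3-fold higher number from compound 1 to compound 4 (0.52 log units; beyond the scatter) as a modest step, in the same direction as both difluorophenyl replacements. Set against those rings, it gives a 1.3-fold higher number from compound 3 to compound 4 (0.12 log units; within the scatter) and a 1.3-fold higher number from compound 2 to compound 4 (0.11 log units; within the scatter) so compounds 2, 3 and 4 cannot be told apart here, and only compound 1 stands clear of the others. Nothing available explains this result.

Going by these compounds, whether a ring bearing an amine or a carboxylic acid would fall with compounds 2, 3 and 4 stays open. So does the effect of a single methoxy group on the phenyl ring.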